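The source may hold more compounds than are shown below. What is called first, only, known or untested is meant among the compounds shown, and "the series" means these compounds.

Values in a physicochemical assay for solubility, measured as kinetic solubility, with a stated time of 1 h, at pH 7.4; a higher number here means a more soluble compound, a lower number a less soluble compound:
Compound 1 `CC(=O)Nc1nc(-c2ccc(Cl)c(Cl)c2)cs1`: < 1000 nM, a limit of the assay
Compound 2 `CC(=O)Nc1nc(-c2cccc(Cl)c2)cs1`: 2000 nM
Compound 3 `CC(=O)Nc1nc(-c2ccc(F)c(Cl)c2)cs1`: 10000 nM

Compound 1 is reported only as a limit. Of the two actual numbers, compound 2 has the lower, and the nearest value lies at a 5.0-fold higher number from compound 2 to compound 3 (0.70 log units; beyond the scatter). Compound 4 `CC(=O)Nc1nc(-c2cccc(O)c2)cs1` differs from compound 2 at one place: hydroxy in place of chloro on an aromatic carbon. Two measured steps also replace a chloro: an at least 2.0-fold higher number from compound 1 to compound 2 (0.30 log units; that floor lies within the scatter), and an at least 10-fold higher number from compound 1 to compound 3 (1.00 log units; beyond the scatter). Neither brings in hydroxy, so they guide the direction more than the size. A modest rise in this assay is therefore expected, with an estimated step of a 7.5-fold higher number from compound 2 to compound 4 (0.88 log units; beyond the scatter). For compound 4 the expected value is 15000 nM, with an estimated range of 4000 nM to 60000 nM.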

Compound 4, solubility: 103000 nM
Compound 4: the middle estimate sits 6.9-fold (0.84 log units) below what was measured, outside the stated range (above it).
By their numbers in this assay, from the lowest: compound 2; then compound 3; then compound 4. At a limit, below all of these: compound 1.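

In this assay, hydroxy in place of chloro on this aromatic carbon gives a 52-fold higher number from compound 2 to compound 4 (1.71 log units; beyond the scatter), a larger step than any earlier one between two actual numbers. The earlier steps shown here exchanged only chloro, fluoro and hydrogen, whereas this one brings in a hydrogen-bond donor and acceptor at the same place. Nothing measured here bears on the reason for the size of this step.

On these data alone, whether the same place would give a similar step with an amine, a carboxylic acid or a methoxy group stays open. So does whether hydroxy would give a similar step elsewhere on the six-membered aromatic ring.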